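Fluorinated benzyl nucleoside analogues: antiproliferative limits and one prediction

The source may hold more compounds than are shown below. What is called first, only, known or untested is meant among the compounds shown, and "the series" means these compounds.

Measured so far in a functional assay on MCF cells (Homo sapiens) for antiproliferative activity, with a stated time of 72 h; a higher number here means a weaker inhibitor, a lower number a stronger inhibitor:
compound 1 `OC[C@H]1O[C@@H](n2cnc3c(NCc4ccc(F)c(F)c4F)ncnc32)[C@H](O)[C@@H]1O` gives > 166000 nM, which is a limit of the assay rather than a number.
compound 2 `OC[C@H]1O[C@@H](n2cnc3c(NCc4ccccc4OC(F)F)ncnc32)[C@H](O)[C@@H]1O` gives > 166000 nM, again only a limit of the assay.

For the measured compounds named here, compound 2 therefore stands at the limit of this assay, and the one step that reaches it, a step that the two limits leave unreadable from compound 1 to compound 2, cannot be read because both of its ends sit at the limit of > 166000 nM in this assay, at which 2 of the 2 values shown sit. The shared core is kept throughout; the only variation is the aryl group on the saturated chain carbon bound to a nitrogen on an aromatic ring.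

Compound 3 `OC[C@H]1O[C@@H](n2cnc3c(NCc4ccc(C(F)(F)F)cc4)ncnc32)[C@H](O)[C@@H]1O` is not yet measured. The change is 4-(trifluoromethyl)phenyl in place of 2-(difluoromethoxy)phenyl on a saturated chain carbon bound to a nitrogen on an aromatic ring. Going by the values given here, the only measured step that bears on exchanging this aryl group is a step that the two limits leave unreadable from compound 1 to compound 2, and its size is not readable, so it gives neither a direction nor a size for this assay. Since both measured compounds sit at the limit of > 166000 nM in this assay, at which 2 of the 2 values shown sit, compound 3 is expected to return only a limit as well. Compound 3 is estimated at 200000 nM, in the range 50000 nM to 1000000 nM. The expected step is a step that the limit leaves unreadable from compound 2 to compound 3, which amounts to nothing beyond the scatter.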

Compound 3, half-maximal inhibitory concentration: > 166000 nM
Compound 3: only a limit was reported; the forecaster's own chance of this, stated with the estimate: 85%; the middle value does not contradict the limit.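

In this assay compound 3 gives > 166000 nM as a limit of the assay, not a number. For the compounds shown here, no new step among compound 1, compound 2 and compound 3 can be read: the limit of > 166000 nM in this assay, at which 3 of the 3 values shown sit. The compounds shown leave open whether any aryl group on the shared core gives a measurable value in this assay and how large such exchanges would be.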